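Working notes: exchanging the aryl group on the sulfonyl

The source may report more compounds than this note shows. Statements on the series, on what has been measured and on what is new or still open speak of the compounds shown alone.

Three compounds of the series have numbers from a functional assay on CHO cells for antagonist activity at 5-hydroxytryptamine receptor 6 (Homo sapiens), read by FLIPR; on this read-out lower numbers stand for stronger inhibition and higher numbers for weaker inhibition. Compound 1 `COc1cccc(N2CCN(C(=O)C3CN(S(=O)(=O)c4ccc(OC)c5ccccc45)c4ccccc43)CC2)c1` gives 63.1 nM. Compound 2 `COc1ccc(S(=O)(=O)N2CC(C(=O)NCCCn3ccnc3)c3ccccc32)c2ccccc12` gives 79.4 nM in this assay. Compound 3 `CN1CCC(N(C)C(=O)C2CN(S(=O)(=O)c3ccc4ccccc4c3)c3ccccc32)CC1` gives 25.1 nM in this assay, the lowest of the three numbers; its steps to compound 1 and to compound 2 both lie beyond the usual scatter, so compound 3 is the strongest inhibitor among the three, with compound 1 nearer to it and compound 2 further away. The three compounds differ from one another in more than one place, so none of these gaps can be tied to a single structural change.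

Compound 4 `Cc1c(S(=O)(=O)N2CC(C(=O)N(C)C3CCN(C)CC3)c3ccccc32)sc2ccc(Cl)cc12` is not yet measured. It differs from compound 3 in one place: 5-chloro-3-methyl-1-benzothiophen-2-yl in place of naphthalen-2-yl on a sulfonyl sulfur. Among the measured compounds shown here, no measured pair shows this exchange, so nothing is known here about its size or direction. Both groups are two-ring aromatic systems, and the rest of the molecule is kept; the step from compound 3 to compound 4 is expected to stay within the scatter, a 1.0-fold lower number from compound 3 to compound 4 (0.00 log units; within the scatter), with no preferred direction. For compound 4 a value of 25 nM is estimated in this assay, with an expected range from 8 nM to 80 nM.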

Compound 4, inhibition constant: 63.1 nM
Estimate against measurement, compound 4: 2.5-fold (0.40 log units) below; the range from low to high includes it.
By their numbers in this assay, from the lowest: compound 3; then compounds 1, 4 and 2 (each within the scatter of the next).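

Among the compounds shown here, this is the first step with a single change, and it shows that the group on the sulfonyl sulfur is not neutral: in this assay 5-chloro-3-methyl-1-benzothiophen-2-yl in place of naphthalen-2-yl gives a 2.5-fold higher number from compound 3 to compound 4 (0.40 log units; beyond the scatter) and so a modest loss of inhibition, beyond the scatter. The earlier compounds shown here could not show this, since they differ in more than one place, whereas here the rest of the molecule is kept and one two-ring aromatic group replaces another. Nothing at hand gives a reason for the step, and it cannot be divided among the sulfur of the five-membered ring, the chlorine and the methyl.

On these data alone, it remains open which of these parts carries the step; 1-benzothiophen-2-yl without substituents, and the same group with only the chlorine or only the methyl, would separate them. As far as these compounds go, it is also open whether a second aromatic ring is needed at this place at all, which a single-ring group such as phenyl or pyridin-3-yl on the sulfonyl sulfur would show.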